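Notes on the peroxide series: compound 2 to compound 4

This account rests on a few compounds, and the source may have more. Where it says the series, first, only, none or still open, it means among the compounds named here.

Three compounds of the shared core have numbers in an ADME assay on the whole organism (strain FVB) for pharmacokinetics, with Mus musculus as the target, read by LC-MS, at a dose of 30 mg/kg by the oral route; a lower number here means less compound in the circulation, a higher number more compound in the circulation at the dose given. Compound 2 `CC(C)(O)CN1CCC(Oc2ccc([C@H]3CC[C@]4(CC3)OOC3(O4)C4CC5CC(C4)CC3C5)cc2)CC1` gives 1810 nM, the highest of the three. Compound 1 `c1cc([C@H]2CC[C@]3(CC2)OOC2(O3)C3CC4CC(C3)CC2C4)ccc1OCCOC1CCNCC1` gives 633 nM and compound 3 `c1cc([C@H]2CC[C@]3(CC2)OOC2(O3)C3CC4CC(C3)CC2C4)ccc1OCC1CCNCC1` gives 465 nM; the step of a 1.4-fold lower number from compound 1 to compound 3 (0.13 log units; within the scatter) lies within the scatter, whereas a 2.9-fold higher number from compound 1 to compound 2 (0.46 log units; beyond the scatter) and a 3.9-fold lower number from compound 2 to compound 3 (0.59 log units; beyond the scatter) are both beyond it.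

Compound 4 `NCCCCOc1ccc([C@H]2CC[C@]3(CC2)OOC2(O3)C3CC4CC(C3)CC2C4)cc1` is not yet measured. Its change from compound 2 is 4-aminobutyl in place of 1-(2-hydroxy-2-methylpropyl)piperidin-4-yl on an oxygen on an aromatic ring. Going by the values given here, the steps that bear on it are the two that touch compound 2, a 2.9-fold higher number from compound 1 to compound 2 (0.46 log units; beyond the scatter) and a 3.9-fold lower number from compound 2 to compound 3 (0.59 log units; beyond the scatter), both of modest size and both placing compound 2 above the other two groups tried on the aromatic oxygen. Among the compounds with values here, the 4-aminobutyl group has no measured precedent, so the exchange is read as a return toward the level of compounds 1 and 3. A lower number is therefore expected for compound 4, estimated as a 3.3-fold lower number from compound 2 to compound 4 (0.52 log units; beyond the scatter). In this assay compound 4 is expected near 550 nM, within 220 nM to 1400 nM.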

Compound 4, maximal plasma concentration: 370 nM
Compound 4: the middle estimate sits 1.5-fold (0.17 log units) above what was measured; the measured number falls inside the stated range.
By their numbers in this assay, from the lowest: compounds 4, 3 and 1 (each within the scatter of the next); then compound 2.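

In this assay, 4-aminobutyl in place of 1-(2-hydroxy-2-methylpropyl)piperidin-4-yl on the aromatic oxygen gives a 4.9-fold lower number from compound 2 to compound 4 (0.69 log units; beyond the scatter), so this change loses the high level of compound 2. With a 1.3-fold lower number from compound 3 to compound 4 (0.10 log units; within the scatter) and a 1.7-fold lower number from compound 1 to compound 4 (0.23 log units; within the scatter) both within the scatter, the ring-free chain of compound 4 cannot be told apart from the groups of compound 1 and compound 3, and having a ring in the group does not by itself set a compound at the level of compound 2; of the four, only compound 2 stands apart, and only it carries the 2-hydroxy-2-methylpropyl group. No supporting measurement bears on why this difference arises.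

Still open, from the compounds shown here alone, is whether the 2-hydroxy-2-methylpropyl group alone carries the higher number. A plain methyl or a 2-hydroxyethyl group on the piperidine, or 2-hydroxy-2-methylpropyl on the amine of the 4-aminobutyl chain, would bear on that.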